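The source may hold more compounds than are shown below. What is called first, only, known or untested is meant among the compounds shown, and "the series" means these compounds.

The three measured compounds share one core. In a functional assay (on this read-out higher numbers stand for weaker inhibition and lower numbers for stronger inhibition), compound 1 `CC(C)=CCOc1ccc2c(c1)OC(c1ccccc1)CC2=O` gives 6070 nM. Compound 2 `CC(C)=CCOc1ccc2c(c1)OC(c1cccc(Cl)c1)CC2=O` carries chloro in place of hydrogen on an aromatic carbon of the phenyl ring, and in this assay compound 2 gives 6300 nM; the step is a 1.0-fold higher number from compound 1 to compound 2 (0.02 log units; within the scatter). Compound 3 `CC(C)=CCOc1cc(O)c2c(c1)OC(c1ccccc1)CC2=O` carries hydroxy in place of hydrogen on an aromatic carbon of the core, and in this assay compound 3 gives 7320 nM; the step is a 1.2-fold higher number from compound 1 to compound 3 (0.08 log units; within the scatter). Compound 3 thus sits in one narrow band with compound 1 and compound 2, all three numbers within the usual scatter of one another, so none of them can be set apart.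

Compound 4 `CC(C)=CCOc1cc(O)c2c(c1)OC(c1ccc(Br)cc1)CC2=O` keeps the hydroxy of compound 3 and differs from it by bromo in place of hydrogen on an aromatic carbon, the bromine sitting para to a large group on the phenyl ring. Among the measured compounds shown here, the only measured step of comparable kind, a chloro added to the same phenyl ring, is a 1.0-fold higher number from compound 1 to compound 2 (0.02 log units; within the scatter), and it lay within the scatter. For the measured compounds named here, no measured step shows how a bromo behaves here, and none combines a change on the phenyl ring with the hydroxy of compound 3. Compound 4 is therefore expected to show a 1.0-fold lower number from compound 3 to compound 4 (0.02 log units; within the scatter), nothing beyond the scatter. Compound 4 is estimated at 7000 nM, with a range from 3500 nM to 14000 nM.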

Compound 4, half-maximal inhibitory concentration: 2770 nM
Estimate against measurement, compound 4: 2.5-fold (0.40 log units) above; measured number outside the range, below it.
By their numbers in this assay, from the lowest: compound 4; then compounds 1, 2 and 3 (each within the scatter of the next).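

In this assay, among the compounds shown here, the change from phenyl to 4-bromophenyl gives a 2.6-fold lower number from compound 3 to compound 4 (0.42 log units; beyond the scatter), the first step in this set that lies beyond the scatter. The phenyl ring therefore responds to substitution at this place, para to a large group, on a compound that carries the hydroxy, whereas the earlier chloro step, a 1.0-fold higher number from compound 1 to compound 2 (0.02 log units; within the scatter), and the hydroxy step, a 1.2-fold higher number from compound 1 to compound 3 (0.08 log units; within the scatter), both stayed within the scatter and gave no sign of this. Nothing available accounts for why the bromo has this effect, and the size of the step stands here as an observation only.

On these data alone, it remains open whether the bromo would give a comparable step on the core of compound 1, without the hydroxy, or whether the step depends on the two groups occurring together. As far as these compounds go, it is equally open whether the step belongs to bromine itself or to any group at this place, a question that a fluoro, a methoxy, a trifluoromethyl or a carboxylic acid in the same position could help to settle.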